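Swapping an aryl group on a sulfonamide nitrogen

A few compounds are considered here, and "the series" means these few. Any claim that something is new, unique, unknown or untested is made for them only; others in the source may bear on it.

Of the compounds shown here, two in this set have been measured in a physicochemical assay for lipophilicity, at pH 7.4; on this read-out higher numbers stand for higher lipophilicity and lower numbers for lower lipophilicity. Among the compounds with values here, compound 1, with the structure `CC(C)CN(c1ccc(N(C)C)cc1)S(=O)(=O)c1ccc2c(c1)C(O)CC(C1CCOCC1)O2`, gives 3.51 in this assay, the lower of the two numbers known so far. Compound 2, with the structure `CCc1ccc(N(CC(C)C)S(=O)(=O)c2ccc3c(c2)C(O)CC(CC2CCOCC2)O3)cc1`, gives 4.44 in this assay, a number that lies higher by more than the usual scatter. Compound 2 differs from compound 1 in more than one place, so these two values alone do not separate the contributions of the individual changes.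

Compound 3, with the structure `Cc1ccc(N(CC(C)C)S(=O)(=O)c2ccc3c(c2)C(O)CC(C2CCOCC2)O3)c(C)c1`, has not yet been measured. It differs from compound 1 in one place: 2,4-dimethylphenyl in place of 4-(dimethylamino)phenyl on a sulfonamide nitrogen. The change removes the only hydrogen-bond acceptor of the departing group and brings in a group of eight carbon atoms with no acceptor at all. For this kind of change, an increase in this assay is expected, moderate in size and beyond the scatter, with the step from compound 1 to compound 3 estimated as a number 0.59 log units higher from compound 1 to compound 3 (beyond the scatter). Compound 3 is therefore expected to give about 4.1 in this assay, within a range of 3.7 to 4.6.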

Compound 3, distribution coefficient: 4.19
Compound 3: the middle estimate sits 0.09 log units below what was measured; the range from low to high includes it.
By their numbers in this assay, from the lowest: compound 1; then compounds 3 and 2 (each within the scatter of the next).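

In this assay, 2,4-dimethylphenyl in place of 4-(dimethylamino)phenyl on a sulfonamide nitrogen gives a number 0.68 log units higher from compound 1 to compound 3 (beyond the scatter). Within the data shown here, this is the first comparison here that changes a single place, and it shows that the aryl group on this nitrogen can by itself shift the read-out by more than the usual scatter, something the comparison of compound 1 with compound 2 could not separate from its other differences. The departing group carries a nitrogen and a hydrogen-bond acceptor that the entering group lacks, but no measurement here tells what lies behind the shift.

This single swap removes the dimethylamino group and adds two methyl groups, so the compounds shown cannot divide the step between the loss and the gain; plain phenyl or 4-methylphenyl on the same nitrogen would help to pull those two parts apart. On these data alone, it also remains open whether the same swap would give a step of similar size with a longer chain, such as hexyl, on that nitrogen, or with a different group elsewhere on the shared core.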